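From 2-fluorophenyl to 1-methyl-1H-pyrazol-4-yl: a cytotoxicity estimate

The source may hold more compounds than are shown below. What is called first, only, known or untested is meant among the compounds shown, and "the series" means these compounds.

Compound 1 `O=c1nc(-c2ccccc2)c2cc(-c3ccc(N4CCCC4)nc3)ccc2[nH]1` gives > 50000 nM
Compound 2 `O=c1nc(-c2ccccc2)c2cc(-c3cnc4ccccc4c3)ccc2[nH]1` gives > 16000 nM
Compound 3 `O=c1nc(-c2ccccc2)c2cc(-c3ccccc3F)ccc2[nH]1` gives 55800 nM

All three compounds were tested in an ADME assay on L6 cells (Rattus norvegicus) for cytotoxicity, read by fluorescence and resazurin assay, with a stated time of 72 h; a higher number here means that more compound is needed for the effect, a lower number that less compound is needed. Compound 1 gives > 50000 nM, which is a limit of the assay and not a number. Compound 2 gives > 16000 nM, which is likewise a limit and not a number. For the measured compounds named here, compound 3 gives 55800 nM, the only actual number, which makes it the one firm reference point.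

Compound 4 `Cn1cc(-c2ccc3[nH]c(=O)nc(-c4ccccc4)c3c2)cn1` has not yet been measured. It keeps the shared core of compound 3 and carries 1-methyl-1H-pyrazol-4-yl in place of 2-fluorophenyl on an aromatic carbon.

Going by the values given here, no pair of measured compounds differing in one place is available, so the data give no direct guide to the effect of this change in this assay. With compound 3 at 55800 nM as the reference, no step beyond the scatter is expected in either direction. The expected step of a 1.1-fold lower number from compound 3 to compound 4 (0.05 log units; within the scatter) is an estimate and stays small. For compound 4 the estimated value is 50000 nM, with an expected range from 15000 nM to 120000 nM.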

Compound 4, half-maximal effective concentration: > 50000 nM
Compound 4 ended at the assay's limit (the forecaster's own chance of this, stated with the estimate: 45%); the middle value lies on the limit itself.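

In this assay compound 4 gives > 50000 nM, which is a limit of the assay and not a number. For the compounds shown here, no step from compound 3 to compound 4 can therefore be read. The compounds shown leave open how large the effect of 1-methyl-1H-pyrazol-4-yl in place of 2-fluorophenyl is in this assay, and in which direction it runs.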